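This account rests on a few compounds, and the source may have more. Where it says the series, first, only, none or still open, it means among the compounds named here.

Three compounds have been measured in a functional assay on MCF7 cells (Homo sapiens) for cytotoxicity, read by MTT assay, with a stated time of 24 h; a higher number here means a weaker inhibitor, a lower number a stronger inhibitor:

Compound 1, `CCc1cc(Br)ccc1Nc1ncnc2cc(OC)c(OCCCSc3nc4ccccc4o3)cc12`, gives 17300 nM.
Compound 2, `COc1ccc(Nc2ncnc3cc(OC)c(OCCCSc4nc5ccccc5o4)cc23)cc1`, gives 13100 nM.
Compound 3, `CCCCc1nc(Cl)c(C=O)n1CCCOc1cc2c(Nc3ccc(Br)cc3CC)ncnc2cc1OC`, gives 6560 nM.

Compound 4, `CCCCc1nc(Cl)c(C=O)n1CCCOc1cc2c(Nc3ccc(OC)cc3)ncnc2cc1OC`, has not yet been measured. It is made from compound 3 by one change, (4-methoxyphenyl in place of 4-bromo-2-ethylphenyl on a nitrogen on an aromatic ring). The same change has already been made once among the measured compounds, from compound 1 to compound 2, where it read 4-methoxyphenyl in place of 4-bromo-2-ethylphenyl on a nitrogen on an aromatic ring and gave a 1.3-fold lower number from compound 1 to compound 2 (0.12 log units; within the scatter). The surroundings of the change are the same in both pairs; what separates the two cores is 2-butyl-4-chloro-5-formyl-1H-imidazol-1-yl in place of (1,3-benzoxazol-2-yl)sulfanyl on a saturated chain carbon, three bonds along the chain from an oxygen on an aromatic ring, a change that gave a 2.6-fold lower number from compound 1 to compound 3 (0.42 log units; beyond the scatter). The values of compound 2 and compound 3 lie close to each other.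

For the measured compounds named here, with only one earlier example, the expectation for compound 4 rests on the step from compound 1 to compound 2: the step from compound 3 to compound 4 is expected to be of about the same small size, a 1.3-fold lower number from compound 3 to compound 4 (0.12 log units; within the scatter), because the earlier one was a 1.3-fold lower number from compound 1 to compound 2 (0.12 log units; within the scatter). Compound 4 is therefore estimated at 5000 nM, most likely between 2500 nM and 10000 nM.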

Compound 4, half-maximal inhibitory concentration: 14000 nM
Estimate against measurement, compound 4: 2.8-fold (0.45 log units) below, outside the stated range (above it).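

In this assay, the swap to 4-methoxyphenyl on the nitrogen does not carry over from one core to the other, since on the core of compound 3 it gives a 2.1-fold higher number from compound 3 to compound 4 (0.33 log units; beyond the scatter): the same change on two cores in this assay, a 1.3-fold lower number (0.12 log units; within the scatter) from compound 1 to compound 2 and a 2.1-fold higher number (0.33 log units; beyond the scatter) from compound 3 to compound 4, 2.8-fold (0.45 log units) apart, beyond the scatter of two such steps

The side-chain swap, read on the same four compounds, tells the same story, since with 4-methoxyphenyl in place it gives a 1.1-fold higher number from compound 2 to compound 4 (0.03 log units; within the scatter), so the lower number seen with 4-bromo-2-ethylphenyl does not reappear: the same change on two cores in this assay, a 2.6-fold lower number (0.42 log units; beyond the scatter) from compound 1 to compound 3 and a 1.1-fold higher number (0.03 log units; within the scatter) from compound 2 to compound 4, 2.8-fold (0.45 log units) apart, beyond the scatter of two such steps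

So in these four compounds the effect of each change depends on the other, but this rests on a single pair of steps in one cell assay and does not show why the two changes interact.

Still open, on these data alone, is which part of 4-bromo-2-ethylphenyl goes with the lower number of compound 3, a question that 4-bromophenyl or 2-ethylphenyl on the same core could answer. Also open, as far as these compounds go, is whether the dependence holds for other groups on the nitrogen, such as 4-chlorophenyl, or with a longer chain to the imidazole.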